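This account rests on a few compounds, and the source may have more. Where it says the series, first, only, none or still open, it means among the compounds named here.

Compound 1 `CC(C)(C)[C@H]1CC[C@H](N(Cc2ccc(C(=O)NCCC(=O)O)cc2)C(=O)Nc2ccc(C#N)cc2)CC1` gives 1050 nM in an in vitro assay on BHK cells for inhibition of Glucagon receptor (Homo sapiens); a lower number here means a stronger inhibitor, a higher number a weaker inhibitor. Compound 2 `O=C(O)CCNC(=O)c1ccc(CN(C(=O)Nc2ccc(OC(F)(F)F)cc2)C2CCC(C(=O)O)CC2)cc1` was tested in the same this assay, and there the result for compound 2 is only a limit of the assay and not a number: compound 2 shows > 10000 nM, which is the limit of > 10000 nM in this assay, at which 1 of the 2 values shown sits. Compound 3 `CCCC1CCC(N(Cc2ccc(C(=O)NCCC(=O)O)cc2)C(=O)Nc2ccc(OC(F)(F)F)cc2)CC1` differs from compound 2 in one place: propyl in place of carboxy on a saturated ring carbon. No measured pair shows this change on its own, so the direction has to be drawn from what is shown elsewhere. Compound 1 carries tert-butyl where compound 2 carries carboxy, though it also differs from compound 3 in its aromatic part. In this assay compound 1 gives a measured number, 1050 nM. On that basis compound 3 is expected to give a measured number in this assay. The step of an at least 6.6-fold lower number from compound 2 to compound 3 (0.82 log units; beyond the scatter) is expected to run towards stronger inhibition. The estimate for compound 3 is 1500 nM, within a range from 400 nM to 6000 nM.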

Compound 3, half-maximal inhibitory concentration: 122 nM
Compound 3: the middle estimate sits 12-fold (1.09 log units) above what was measured; measured number below the stated range.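

Going from 4-carboxycyclohexyl to 4-propylcyclohexyl, a change in one place only, gives an at least 81-fold lower number from compound 2 to compound 3 (1.91 log units; beyond the scatter) in this assay. Among the compounds shown here, this is the first clean evidence that the group on this saturated ring carbon matters strongly for the read-out, and that a chain of carbon alone is tolerated far better here than carboxy. The true size of the step is not known, because compound 2 stands at a limit of the assay and not at a number: the limit of > 10000 nM in this assay, at which 1 of the 3 values shown sits.

For the compounds shown here, with only two groups compared at this place, the step cannot separate losing carboxy from gaining propyl. From the compounds shown here alone, it remains open whether an amine, a hydroxyl group or a longer chain on this ring carbon would give a stronger or a weaker inhibitor.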